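Cyclopropyl for ethyl on the amide of compound 2

This account rests on a few compounds, and the source may have more. Where it says the series, first, only, none or still open, it means among the compounds named here.

Measured so far:
compound 1, `C[C@@H]1CN(c2nc(-c3cnn(C)c3)cnc2C#N)CCN1C(=O)C1CC1`: 39 mL/min/kg
compound 2, `CCC(=O)N1CCN(c2nc(-c3cnn(C)c3)ncc2C#N)C[C@H]1C`: < 36 mL/min/kg

The account concerns two compounds measured in an ADME assay on microsomes from liver (Rattus norvegicus) for pharmacokinetics (a higher number here means faster removal of the compound, a lower number slower removal), and one that is not. Compound 1 carries a cyclopropylcarbonyl on its ring nitrogen and in this assay compound 1 gives 39 mL/min/kg. Compound 2 carries a propanoyl instead, on a core that differs from that of compound 1, and in this assay compound 2 gives < 36 mL/min/kg, which is a limit of the assay and not a number. Among the compounds with values here, compound 2 therefore stands only at or under that limit, as the limit of < 36 mL/min/kg in this assay, at which 1 of the 2 values shown sits, shows, and no step between the two measured compounds is counted.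

Compound 3, `C[C@@H]1CN(c2nc(-c3cnn(C)c3)ncc2C#N)CCN1C(=O)C1CC1`, keeps the core of compound 2 and differs from it in one place: cyclopropyl in place of ethyl on a carbonyl carbon. Within the data shown here, with no measured step in hand, the expected change from compound 2 to compound 3 is a number no lower from compound 2 to compound 3 (the limit leaves the size open), a step of no more than the usual scatter in either direction. Compound 3 is accordingly estimated at 36 mL/min/kg, within a range from 18 mL/min/kg to 65 mL/min/kg.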

Compound 3, clearance: < 36 mL/min/kg
Compound 3 was reported as a limit; the forecaster's own chance of this, stated with the estimate: 45%; the middle value lies on the limit itself.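

In this assay compound 2 and compound 3 are each reported as a limit and not a number, so no step can be read between them: the limit of < 36 mL/min/kg in this assay, at which 2 of the 3 values shown sit. The compounds shown leave open where compound 2 and compound 3 actually lie, and so whether cyclopropyl in place of ethyl on a carbonyl carbon shifts clearance at all.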